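Carbamate aryl swap: difluorophenyl to chlorophenyl

A few compounds are considered here, and "the series" means these few. Any claim that something is new, unique, unknown or untested is made for them only; others in the source may bear on it.

Compound 1 `COc1ccc(CC(=O)O)cc1-c1ccc(C(F)(F)F)cc1CN(C(=O)OCc1ccccc1)C1CCCC1`: 11 nM in an in vitro assay on 293T cells for displacement of a labelled ligand from prostaglandin D2 receptor 2 (Homo sapiens), read by scintillation counting; a higher number here means a weaker inhibitor, a lower number a stronger inhibitor
Compound 2 `COc1ccc(CC(=O)O)cc1-c1ccc(C(F)(F)F)cc1CNC(=O)OCc1ccccc1`: 45 nM
Compound 3 `CCN(Cc1cc(C(F)(F)F)ccc1-c1cc(CC(=O)O)ccc1OC)C(=O)OCc1cc(F)cc(F)c1`: 3 nM

Compound 3 gives the lowest number of the three in this assay, with compound 1 nearest and compound 2 furthest. For the measured compounds named here, the only step that can be read directly, a 4.1-fold higher number from compound 1 to compound 2 (0.61 log units; beyond the scatter), concerns the amide-type nitrogen and not the carbamate aryl group. Compound 4 `CCN(Cc1cc(C(F)(F)F)ccc1-c1cc(CC(=O)O)ccc1OC)C(=O)OCc1cccc(Cl)c1` differs from compound 3 by 3-chlorophenyl in place of 3,5-difluorophenyl on a saturated chain carbon bound to an oxygen next to a carbonyl group. Going by the values given here, no measured pair isolates this change, and compound 1 and compound 3 differ in more than one place, so their values do not split it. Among the compounds with values here, with no precedent for the halogen pattern on this ring, the step of a 1.3-fold higher number from compound 3 to compound 4 (0.12 log units; within the scatter) is expected to be small, without a clear direction. Compound 4 is accordingly estimated at 4 nM, range 1.5 nM to 12 nM.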

Compound 4, half-maximal inhibitory concentration: 2 nM
The estimate for compound 4 lay 2.0-fold (0.30 log units) above the measured number, and the stated range covers the measured number.
By their numbers in this assay, from the lowest: compounds 4 and 3 (each within the scatter of the next); then compound 1; then compound 2.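

At the saturated chain carbon bound to an oxygen next to a carbonyl group, the change from 3,5-difluorophenyl to 3-chlorophenyl gives a 1.5-fold lower number from compound 3 to compound 4 (0.18 log units; within the scatter) in this assay. For the compounds shown here, this is the first direct reading at this position, and it does not separate the two halogen patterns, so the low number of compound 3 does not rest on the 3,5-difluorophenyl group alone. No supporting data bear on why the two groups match.

Going by these compounds, whether any halogen is needed stays open, since other steps between these compounds cannot be read. Plain phenyl with the ethyl group kept on the nitrogen, or a nitrile or methoxy group on this ring, would test this.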